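Bromo in place of hydrogen on compound 2

This account rests on a few compounds, and the source may have more. Where it says the series, first, only, none or still open, it means among the compounds named here.

Compound 1 `CCCCCC(CCO)n1c(Br)nc2c(Cl)ncnc21` gives 18300 nM
Compound 2 `CCCCCCCC(CCO)n1cnc2c(Cl)ncnc21` gives 4160 nM

In a functional assay on HCT-116 cells (Homo sapiens) for antiproliferative activity, read by MTT assay, with a stated time of 48 h (a lower number here means a stronger inhibitor, a higher number a weaker inhibitor), compound 2 holds the lower of the two numbers (4160 nM), and the gap to compound 1 (18300 nM) lies beyond the usual scatter. Compound 3 `CCCCCCCC(CCO)n1c(Br)nc2c(Cl)ncnc21` is compound 2 with bromo in place of hydrogen on an aromatic carbon, on the carbon between two ring nitrogen atoms. Among the measured compounds shown here, no measured pair differs in one place only, so the effect of this change has not been measured on its own. Compound 1 already bears bromo at this carbon and gives the higher number (18300 nM), which points to a small rise rather than a fall. The expected change is a 1.7-fold higher number from compound 2 to compound 3 (0.23 log units; within the scatter) (a weakening near the edge of the scatter). Compound 3 is estimated at 7000 nM (2500 nM to 20000 nM).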

Compound 3, half-maximal inhibitory concentration: 16200 nM
Compound 3: middle estimate off by 2.3-fold (0.36 log units), on the low side; measured number inside the range.
By their numbers in this assay, from the lowest: compound 2; then compounds 3 and 1 (each within the scatter of the next).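

In this assay bromo in place of hydrogen on the aromatic carbon between two ring nitrogen atoms now has a measured effect of its own (a 3.9-fold higher number from compound 2 to compound 3 (0.59 log units; beyond the scatter)), and in this pair the compound with hydrogen holds the lower number. With bromo in place, ethyl in place of hydrogen on a saturated chain carbon, six bonds along the chain from an aromatic nitrogen, leaves the number within the scatter (a 1.1-fold lower number from compound 1 to compound 3 (0.05 log units; within the scatter)), so this chain change has no readable effect in this pair. No measurement on hand gives a reason for the bromo step.

As far as these compounds go, whether the ethyl change stays as small with hydrogen at this carbon remains open. Also open, from the compounds shown here alone, is how a methyl group or an amine at this carbon would compare with hydrogen and bromo.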